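Swapping One Group on a Sulfonyl Sulfur

The source may report more compounds than this note shows. Statements on the series, on what has been measured and on what is new or still open speak of the compounds shown alone.

Compound 3 `CC1=NN(S(=O)(=O)c2ccccc2C)C(c2cc(Br)ccc2O)C1` gives 48100 nM in a functional assay on SGC-7901 cells (Homo sapiens) for antiproliferative activity, read by MTT assay, with a stated time of 48 h (on this read-out higher numbers stand for an effect only at larger amounts of compound and lower numbers for an effect already at smaller amounts), and stands level, within the usual scatter, with compound 1 `COc1ccc(C(=O)N2N=C(C)CC2c2ccccc2O)cc1` at 45700 nM in this assay on the same scale. Compound 2 `CC1=NN(C(=O)CCl)C(c2cc(Br)ccc2O)C1` shows a clearly lower number, 9210 nM in this assay, so it acts at smaller amounts. The gap between compound 2 and compound 3 lies beyond the scatter.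

Among the compounds with values here, compound 4 `COc1ccc(S(=O)(=O)N2N=C(C)CC2c2cc(Br)ccc2O)cc1` keeps everything in compound 3 except one group, with 4-methoxyphenyl in place of 2-methylphenyl on a sulfonyl sulfur (the only structural change).

Within the data shown here, no measured pair shows this swap directly, so the guide is thin. Compound 1 also carries a 4-methoxyphenyl, though it differs elsewhere too, and its 45700 nM sits level with compound 3 in the data. No step beyond the scatter is therefore expected in this assay in either direction. The estimated step is a 1.1-fold lower number from compound 3 to compound 4 (0.06 log units; within the scatter) and would stay within the scatter. For compound 4 the estimated value is 42000 nM with 16000 nM to 100000 nM as its expected range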

Compound 4, half-maximal effective concentration: 21100 nM
Compound 4: middle estimate off by 2.0-fold (0.30 log units), on the high side, and the stated range covers the measured number.
By their numbers in this assay, from the lowest: compound 2; then compound 4; then compounds 1 and 3 (each within the scatter of the next).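

On the sulfonyl sulfur, replacing 2-methylphenyl with 4-methoxyphenyl gives a 2.3-fold lower number from compound 3 to compound 4 (0.36 log units; beyond the scatter) in this assay, a modest step but one beyond the usual scatter. Within the data shown here, no two earlier compounds differed in only one place, so this pair gives the first direct reading of a single change, and it shows that the number responds to the group carried at this position. No measurement here explains why the number moves.

This one swap leaves open whether gaining the methoxy group or losing the methyl group matters more, as both happen together. It also leaves open how the number would respond to a simple methyl group on the sulfur, or to a phenyl ring carrying an amine or a carboxylic acid.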